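Removing a fluoro substituent from a salicylanilide-type Jurkat cytotoxin

The source may hold more compounds than are shown below. What is called first, only, known or untested is meant among the compounds shown, and "the series" means these compounds.

Measured so far:
compound 1, `N#Cc1ccc(NC(=O)c2ccc3cccnc3c2O)c(F)c1`, 420 nM
compound 2, `O=C(Nc1ccc(C(F)(F)F)cc1)c1cc(Br)c(F)cc1O`, 880 nM
compound 3, `N#Cc1ccc(NC(=O)c2ccc3cccnc3c2O)cc1`, 180 nM

Of the compounds shown here, three have been tested in a functional assay on Jurkat cells (Homo sapiens) for cytotoxicity, read by luminescence and CellTiter-Glo, with a stated time of 3 days; on this read-out higher numbers stand for weaker inhibition and lower numbers for stronger inhibition. Compound 3 gives the lowest number, and compound 2 gives the highest; the difference between the two cores of compound 1 and compound 2 is not broken down here.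

One structural change has been measured directly: hydrogen in place of fluoro on an aromatic carbon, which gave a 2.3-fold lower number from compound 1 to compound 3 (0.37 log units; beyond the scatter). Compound 4, `O=C(Nc1ccc(C(F)(F)F)cc1)c1cc(Br)ccc1O`, is the unmeasured partner of compound 2 and differs from it by hydrogen in place of fluoro on an aromatic carbon. This is the same kind of change as from compound 1 to compound 3, but not the same one: in compound 1 the fluoro sits ortho to a large group and meta to a cyano group, whereas in compound 2 it sits ortho to a bromo group, meta to a hydroxy group and para to a large group.

Resting on the single earlier step, in this assay the step from compound 2 to compound 4 is expected to be about a 1.8-fold lower number from compound 2 to compound 4 (0.25 log units; within the scatter), a modest lowering of the number. Compound 4 is therefore estimated at about 500 nM, with a plausible range from 200 nM to 1500 nM.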

Compound 4, half-maximal inhibitory concentration: 620 nM
Estimate against measurement, compound 4: 1.2-fold (0.09 log units) below, within the range that was stated.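

On the core of compound 2, replacing the fluoro with hydrogen gave a 1.4-fold lower number from compound 2 to compound 4 (0.15 log units; within the scatter) in this assay, so this step alone does not separate compound 2 from compound 4. Set beside the earlier step, the same change on the two cores shows no difference that stands clear of the scatter: the same change on two cores in this assay, a 2.3-fold lower number (0.37 log units; beyond the scatter) from compound 1 to compound 3 and a 1.4-fold lower number (0.15 log units; within the scatter) from compound 2 to compound 4, 1.6-fold (0.22 log units) apart, within the scatter of two such steps. This agrees with the change carrying over from one core to the other, but two pairs do not establish a rule for the series, and since the fluoro sits in a different setting on each core, the effect of the core cannot be told apart from that of the surroundings.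

The compounds shown leave open whether a chloro group, a methoxy group or an amine in the place of the fluoro would give a similar number. They also leave open whether the step would hold on a core without the bromo group or the hydroxy group.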